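The source may report more compounds than this note shows. Statements on the series, on what has been measured and on what is new or still open speak of the compounds shown alone.

Compound 1 `CN(Cc1cccs1)C1CCN(CCCc2c[nH]c3ccc(-n4cnnc4)cc23)CC1` and compound 2 `C[C@@H](NC1CCN(CCCc2c[nH]c3ccc(-n4ccnc4)cc23)CC1)c1ccccc1` share a core and differ in the amine borne by the saturated ring. In an assay on CHO cells for displacement of a labelled ligand from 5-hydroxytryptamine receptor 1D (Homo sapiens) (on this read-out higher numbers stand for weaker inhibition and lower numbers for stronger inhibition), compound 1 gives 4.3 nM, the higher of the two numbers recorded, while compound 2 gives 4.2 nM, a gap that lies within the scatter. Compound 3 `c1ccc(NCC2CCN(CCCc3c[nH]c4ccc(-n5cnnc5)cc34)CC2)nc1` has not been measured in this assay. It differs from compound 1 by ((pyridin-2-yl)amino)methyl in place of methyl((thiophen-2-yl)methyl)amino on a saturated ring carbon. Among the measured compounds shown here, no measured pair shows this change, so the expected step of a 2.3-fold higher number from compound 1 to compound 3 (0.37 log units; beyond the scatter) is only a guess leaning slightly toward weaker inhibition. For compound 3 the expected result is 10 nM, within 2 nM to 50 nM.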

Compound 3, half-maximal inhibitory concentration: 1.7 nM
For compound 3 the middle estimate is 5.9-fold (0.77 log units) above the measured one, outside the stated range (below it).
By their numbers in this assay, from the lowest: compound 3; then compounds 2 and 1 (each within the scatter of the next).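

In this assay the swap of methyl((thiophen-2-yl)methyl)amino for ((pyridin-2-yl)amino)methyl on the saturated ring carbon gives a 2.5-fold lower number from compound 1 to compound 3 (0.40 log units; beyond the scatter) and so shows that this position accepts a different aromatic ring and a different link to it, with a modest gain in inhibition. The entering group carries a hydrogen-bond donor that the leaving group lacks, but nothing available ties the step to that or to any other feature. The compounds shown leave open whether a phenyl ring in place of the pyridin-2-yl ring, or a longer chain before the amine, would hold this gain.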